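Adding 4-cyanophenyl to compound 2: expected cytotoxicity step

A few compounds are considered here, and "the series" means these few. Any claim that something is new, unique, unknown or untested is made for them only; others in the source may bear on it.

compound 1 `C=CC(=O)N1C(=O)CC(c2ccc(C)cc2)Sc2ccccc21`: 87600 nM
compound 2 `C=CC(=O)N1C(=O)CCSc2ccccc21`: 565000 nM
compound 3 `C=CC(=O)N1C(=O)CC(c2ccccc2C(F)(F)F)Sc2ccccc21`: 84400 nM

In a functional assay on MOLT-4 cells (Homo sapiens) for cytotoxicity, read by CCK-8 assay, with a stated time of 24 h (a lower number here means a stronger inhibitor, a higher number a weaker inhibitor), compound 2 stands highest of the three at 565000 nM, and so is the weakest inhibitor. The values of compound 1 and compound 3 lie within the scatter of each other.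

The unmeasured compound 4 `C=CC(=O)N1C(=O)CC(c2ccc(C#N)cc2)Sc2ccccc21` differs from compound 2 by 4-cyanophenyl in place of hydrogen on a saturated ring carbon, next to the ring sulfur: 4-cyanophenyl in place of hydrogen on a saturated ring carbon.

For the measured compounds named here, one measured step bears on this change: a 6.4-fold higher number from compound 1 to compound 2 (0.81 log units; beyond the scatter). It is modest but beyond the scatter, and it removes a 4-methylphenyl group, so the change to compound 4 runs the opposite way. Compound 3, with a substituted phenyl group on that carbon, gives 84400 nM, which fits the same picture. Going by the values given here, no measured compound carries a nitrile, so a step of similar size toward a lower number is expected, with some uncertainty.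

The expected change is a 6.6-fold lower number from compound 2 to compound 4 (0.82 log units; beyond the scatter).

For compound 4 the estimated value is 85000 nM, with an expected range of 38000 nM to 190000 nM.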

Compound 4, half-maximal inhibitory concentration: 88700 nM
Estimate against measurement, compound 4: 1.0-fold (0.02 log units) below; measured number inside the range.
By their numbers in this assay, from the lowest: compounds 3, 1 and 4 (each within the scatter of the next); then compound 2.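

Putting 4-cyanophenyl on the saturated ring carbon gives a 6.4-fold lower number from compound 2 to compound 4 (0.80 log units; beyond the scatter) in this assay, so the lower number seen with 4-methylphenyl in compound 1 is not confined to that one group. Cyano in place of methyl on the aromatic carbon gives a 1.0-fold higher number from compound 1 to compound 4 (0.01 log units; within the scatter), so in this pair the number follows the presence of the substituted phenyl ring and does not separate methyl from cyano. Nothing at hand gives a reason for either step.

Open, as far as these compounds go, is whether an amine or a carboxylic acid on that phenyl ring would also leave the number unchanged. Also open, from the compounds shown here alone, is whether a group without an aromatic ring, such as a longer alkyl chain, would give a step like that of 4-cyanophenyl on the saturated ring carbon.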